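Shortening the amide chain: compound 3 to compound 4

The source may hold more compounds than are shown below. What is called first, only, known or untested is meant among the compounds shown, and "the series" means these compounds.

Compound 1 `CNC(=O)c1cc(OC)n(-c2ccccc2)n1`: 57.9%
Compound 2 `COc1cc(C(=O)N(C)C)nn1-c1ccccc1`: 47.5%
Compound 3 `CCCCNC(=O)c1cc(OC)n(-c2ccccc2)n1`: 20.6%

In a functional assay on the whole organism (strain Wistar) for inhibition, with Rattus norvegicus as the target, read by paw edema, with stated times of 30 min and 3 h, at a dose of 100 mg/kg by the oral route (on this read-out lower numbers stand for less inhibition and higher numbers for more inhibition at the one dose given (going by the name of the read-out)), compound 3 stands lowest of the three measured compounds, with compound 2 nearest and compound 1 furthest. Compound 4 `COc1cc(C(=O)NC(C)C)nn1-c1ccccc1` differs from compound 3 by isopropyl in place of butyl on an amide-type nitrogen.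

Among the compounds with values here, three measured steps bear on this change, since all of them alter what sits on the same amide-type nitrogen. The step of a number 10.4 percentage points lower from compound 1 to compound 2 (beyond the scatter). The step of a number 37.3 percentage points lower from compound 1 to compound 3 (beyond the scatter). The step of a number 26.9 percentage points lower from compound 2 to compound 3 (beyond the scatter). Across these three compounds the smaller the group on the amide-type nitrogen, the higher the number, and compound 3, carrying the longest chain, sits lowest; no measured compound runs against this within the set shown. Compound 4 carries a chain of fewer carbons than compound 3, and so a rise is expected in this assay, though a branched chain has not been measured here and the size of the rise is uncertain. The expected step is a number 14.4 percentage points higher from compound 3 to compound 4 (beyond the scatter). For compound 4 the estimated value is 35%, within a range from 20% to 52%.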

Compound 4, a percentage reported as inhibition, in the whole organism at one dose (the size of the read-out at that dose, not a potency): 24.8%
For compound 4 the middle estimate is 10.2 percentage points above the measured one; the measured number falls inside the stated range.
By their numbers in this assay, from the lowest: compounds 3 and 4 (each within the scatter of the next); then compound 2; then compound 1.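

In this assay, within the data shown here, the swap of butyl for isopropyl on the amide-type nitrogen gives a number 4.2 percentage points higher from compound 3 to compound 4 (within the scatter) and so leaves the two chains indistinguishable, which means that the trend among the earlier compounds, where a smaller group went with a higher number, does not extend to this pair. Compound 4 instead stays well apart from the compounds with the smallest groups, with isopropylamino in place of dimethylamino giving a number 22.7 percentage points lower from compound 2 to compound 4 (beyond the scatter) and isopropyl in place of methyl giving a number 33.1 percentage points lower from compound 1 to compound 4 (beyond the scatter), so the low level seen for butyl is already present with isopropyl. Nothing available explains why these two groups read alike.

The compounds shown leave open where the number drops on going up from methyl to isopropyl, a point on which an ethyl group on the amide-type nitrogen would bear, and whether an unbranched propyl chain would read like isopropyl. They also leave open whether a chain ending in a hydroxyl group, an amine or a carboxylic acid would stay at the level of compound 3 and compound 4 or move away from it.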